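The source may hold more compounds than are shown below. What is called first, only, known or untested is meant among the compounds shown, and "the series" means these compounds.

The measured compounds, one by one:

Compound 1, `CC1(C[C@@H](O)C(=O)N2N=CC[C@H]2C(=O)NCc2cc(Cl)ccc2-n2cnnn2)CC1`; in an ADME assay on liver for metabolic stability, with Liver microsome (Homo sapiens) as the target, read by LC-MS, using microsomes (a higher number here means faster removal of the compound, a lower number slower removal), compound 1 gives < 12 mL.min-1.g-1, which is a limit of the assay and not a number.

Compound 2, `CC(C)(C)[C@@H](O)C(=O)N1N=CC[C@H]1C(=O)NCc1cc(Cl)ccc1-n1cnnn1`; in this assay compound 2 gives < 12 mL.min-1.g-1, again a limit rather than a number.

For the measured compounds named here, compound 3, `CC(C)(C)[C@@H](O)C(=O)N1C[C@H]2C[C@H]2[C@H]1C(=O)NCc1cc(Cl)ccc1-n1cnnn1`; in this assay compound 3 gives 22 mL.min-1.g-1, the only actual number among the three.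

Compound 4, `CC1(C[C@@H](O)C(=O)N2C[C@H]3C[C@H]3[C@H]2C(=O)NCc2cc(Cl)ccc2-n2cnnn2)CC1`, has not yet been measured in this assay. It is related to compound 3 by one change, ((1-methylcyclopropyl)methyl in place of tert-butyl on a saturated chain carbon bound to a carbonyl carbon and an oxygen on a saturated carbon). The same change, ((1-methylcyclopropyl)methyl in place of tert-butyl on a saturated chain carbon bound to a carbonyl carbon and an oxygen on a saturated carbon), links the two measured compounds, and its step there is a step that the two limits leave unreadable from compound 2 to compound 1. Both ends of that step are limits, so no size can be read from it; what can be said is the limit of < 12 mL.min-1.g-1 in this assay, at which 2 of the 3 values shown sit. The two cores, that of compound 2 and that of compound 3, differ in a way that is not broken down here. The place of the change is described in the same words for both pairs, so it is the same change in both.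

For compound 4 the expected step is a 1.1-fold lower number from compound 3 to compound 4 (0.04 log units; within the scatter); this rests on a step that the two limits leave unreadable from compound 2 to compound 1, which gave no readable size, and on compound 3 sitting at 22 mL.min-1.g-1. Compound 4 is thus estimated at 20 mL.min-1.g-1, with a likely range from 9 mL.min-1.g-1 to 45 mL.min-1.g-1.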

Compound 4, intrinsic clearance in microsomes: 12 mL.min-1.g-1
Compound 4: the middle estimate sits 1.7-fold (0.22 log units) above what was measured; measured number inside the range.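

In this assay, putting (1-methylcyclopropyl)methyl in place of tert-butyl gives a 1.8-fold lower number from compound 3 to compound 4 (0.26 log units; within the scatter), so on this core the change cannot be told apart from the ordinary spread of repeated measurements. This does not prove that the change has no effect; a single pair of compounds can only show that any effect here is too small to separate from that spread. Whether the result carries over from one core to another remains unanswered, because the same change on the other core, the step from compound 2 to compound 1, cannot be read, with a limit of the assay at both of its ends: the limit of < 12 mL.min-1.g-1 in this assay, at which 2 of the 4 values shown sit.

The compounds shown carry only these two all-carbon groups on a saturated chain carbon bound to a carbonyl carbon and an oxygen on a saturated carbon, so it stays open how an amine, a carboxylic acid or a longer chain in that place would read in this assay. On these data alone, it also stays open whether the two groups would give a readable step on a third core, which is what a test of this change's transfer between cores would need.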